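Swapping an aryl hydrogen for chloro on a sulfonamide

This account rests on a few compounds, and the source may have more. Where it says the series, first, only, none or still open, it means among the compounds named here.

Of the compounds shown here, two with a shared core have been tested in a functional assay on KB cells (Homo sapiens) for antiproliferative activity, read by MTT assay, with a stated time of 72 h; on this read-out lower numbers stand for stronger inhibition and higher numbers for weaker inhibition. Compound 1 `CN(C(=O)C(C)(C)C)c1ccc2[nH]c(-c3n[nH]c4ccccc34)cc2n1` carries a (tert-butyl)carbonyl on a nitrogen on an aromatic ring and gives 8390 nM in this assay. Compound 2 `CN(c1ccc2[nH]c(-c3n[nH]c4ccccc34)cc2n1)S(=O)(=O)c1ccccc1` replaces that group with phenylsulfonyl and gives 2400 nM. Among the compounds with values here, this single change produced a 3.5-fold lower number from compound 1 to compound 2 (0.54 log units; beyond the scatter), so compound 2 holds the lowest number of the two, with compound 1 as its only neighbour.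

Compound 3 `CN(c1ccc2[nH]c(-c3n[nH]c4ccccc34)cc2n1)S(=O)(=O)c1ccc(Cl)cc1` is built from compound 2 by one further change: chloro in place of hydrogen on an aromatic carbon. The chloro sits on an aromatic carbon of a six-membered aromatic ring of carbon only, para to a large group. Within the data shown here, no measured step touches this kind of change; the only step known, from compound 1 to compound 2, concerns a different part of the molecule and gives no guide to what a chloro on the phenyl ring does. The expected step for compound 3 is therefore small, and a 1.4-fold lower number from compound 2 to compound 3 (0.15 log units; within the scatter) is the estimate, essentially none beyond the scatter. In this assay compound 3 is expected to give 1700 nM, with a range from 500 nM to 6000 nM.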

Compound 3, half-maximal inhibitory concentration: 8350 nM
Estimate against measurement, compound 3: 4.9-fold (0.69 log units) below; the measured number lies above the stated range.
By their numbers in this assay, from the lowest: compound 2; then compounds 3 and 1 (each within the scatter of the next).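

In this assay, adding a chloro on an aromatic carbon of the phenyl ring, para to a large group, is not a neutral change: it gives a 3.5-fold higher number from compound 2 to compound 3 (0.54 log units; beyond the scatter). This also means that the advantage of phenylsulfonyl over (tert-butyl)carbonyl does not carry over to (4-chlorophenyl)sulfonyl, as the comparison gives a 1.0-fold lower number from compound 1 to compound 3 (0.00 log units; within the scatter), so a sulfonyl group on that nitrogen is not enough by itself for the lower number, and the outer ring matters as well. Nothing measured here helps to explain why a single chlorine atom has this effect.

The compounds shown leave open whether this result belongs to chloro alone or to any group placed there, which a fluoro, a methyl or a methoxy at the same place could begin to separate. They also leave open how the number would respond to an amine or a carboxylic acid at that place, or to a methyl on the sulfonyl in place of the whole phenyl ring.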